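Swapping an anilino group for cyclohexylamino on a shared core

The source may report more compounds than this note shows. Statements on the series, on what has been measured and on what is new or still open speak of the compounds shown alone.

For the measured compounds named here, compound 1 `Cc1ccc(NC2=CC(=O)c3c(nc4n3[C@H]3OC[C@@H](O)[C@H]3OC4)C2=O)cc1` is one of two compounds measured in a functional assay on MGC-803 cells (Homo sapiens) for inhibition, read by sulforhodamine B assay; on this read-out higher numbers stand for weaker inhibition and lower numbers for stronger inhibition. In this assay compound 1 gives 1550 nM, the higher of the two numbers; compound 2 `Cc1ccc(NC2=CC(=O)c3nc4n(c3C2=O)[C@H]2OC[C@@H](O)[C@H]2OC4)cc1C` gives 860 nM, and the two values lie within the scatter of each other. Compound 3 `O=C1C(NC2CCCCC2)=CC(=O)c2c1nc1n2[C@H]2OC[C@@H](O)[C@H]2OC1` has not yet been measured. It differs from compound 1 only by cyclohexyl in place of 4-methylphenyl on an amine nitrogen. Going by the values given here, no measured pair shows what this change does. A modest step toward weaker inhibition is expected in this assay, as a 1.9-fold higher number from compound 1 to compound 3 (0.29 log units; within the scatter). Compound 3 is therefore estimated to give 3000 nM, with a range from 1000 nM to 10000 nM.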

Compound 3, half-maximal inhibitory concentration: > 8000 nM
Compound 3: only a limit was reported; the forecaster's own chance of this, stated with the estimate: 5%; at least 2.6-fold (0.42 log units) between middle value and limit.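

Cyclohexyl in place of 4-methylphenyl on the amine nitrogen gives an at least 5.1-fold higher number from compound 1 to compound 3 (0.71 log units; beyond the scatter) in this assay, a change the earlier compounds could not show. On this core, then, a six-membered carbon ring on the amine nitrogen is not interchangeable with 4-methylphenyl. The step rests on a limit and not on a number: the limit of > 8000 nM in this assay, at which 1 of the 3 values shown sits.

On these data alone, how far inhibition falls for compound 3 stays open, as does whether the step follows from the loss of aromaticity or of the methyl group. As far as these compounds go, whether plain phenyl, benzyl or cyclopentyl on this nitrogen would behave like 4-methylphenyl also remains unknown.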